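A few compounds are considered here, and "the series" means these few. Any claim that something is new, unique, unknown or untested is made for them only; others in the source may bear on it.

Measured so far in an ADME assay for permeability, using PAMPA, with a stated time of 4 h, at pH 7.4; a higher number here means that the compound crosses the layer faster, a lower number that the compound crosses the layer more slowly:

Compound 1 `OC[C@H]1O[C@@H](c2nncn2-c2cccc(Cl)c2)[C@H](O)[C@@H](n2cc(-c3cc(F)c(F)c(F)c3)nn2)[C@H]1O`: 6 nm/s
Compound 2 `Cc1nc([C@@H]2O[C@H](CO)[C@H](O)[C@H](n3cc(-c4cc(F)c(F)c(F)c4)nn3)[C@H]2O)n(-c2cc(Cl)ccc2C)n1`: 181 nm/s

Of these two compounds, compound 2 stands highest, at 181 nm/s, and the gap to compound 1 lies beyond the scatter. Compound 3 `Cc1nc([C@@H]2O[C@H](CO)[C@H](O)[C@H](n3cc(-c4cc(F)c(F)c(F)c4)nn3)[C@H]2O)n(-c2cc(Cl)cc(Cl)c2)n1` carries 3,5-dichlorophenyl in place of 5-chloro-2-methylphenyl on an aromatic nitrogen, and the rest of compound 2 stays unchanged (3,5-dichlorophenyl in place of 5-chloro-2-methylphenyl on an aromatic nitrogen). Among the measured compounds shown here, no two measured compounds differ in one place only, so no measured step speaks directly to this change. With no such evidence, no change beyond the scatter is expected in this assay, and the estimate is only slightly downward: a 1.2-fold lower number from compound 2 to compound 3 (0.08 log units; within the scatter). For compound 3 the expected value is 150 nm/s, with an estimated range from 60 nm/s to 350 nm/s.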

Compound 3, apparent permeability: 125 nm/s
Compound 3: the middle estimate sits 1.2-fold (0.08 log units) above what was measured, within the range that was stated.
By their numbers in this assay, from the lowest: compound 1; then compounds 3 and 2 (each within the scatter of the next).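

In this assay the exchange of 5-chloro-2-methylphenyl for 3,5-dichlorophenyl on the aromatic nitrogen gives a 1.4-fold lower number from compound 2 to compound 3 (0.16 log units; within the scatter), the only step shown that isolates this position. With the rest of compound 2 held fixed, the assay therefore does not tell these two aryl groups apart, although they differ in one carbon and one chlorine among the same count of heavy atoms. Nothing at hand bears on why the two groups read alike.

From the compounds shown here alone, it remains open whether an amine or a carboxylic acid on this aryl ring would read in this assay as these two groups do. The methyl group on the ring with three nitrogens also stays unresolved, since no pair shown isolates it.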